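The compounds below may be only part of what the source reports. "The series", "measured", "known", "first", "only" and "open" are said of these compounds alone.

Three ureas on a shared core have been measured in a functional assay on MV4-11 cells (Homo sapiens) for cytotoxicity, read by MTT assay, with a stated time of 72 h; a higher number here means a weaker inhibitor, a lower number a stronger inhibitor. Compound 1 `CC(C)(C)c1cc(NC(=O)Nc2ccc(-c3cn4ccccc4n3)cc2)no1` gives 3.09 nM. Compound 2 `CC(C)(C)c1cc(NC(=O)Nc2ccc(-c3cn4ccc(Cl)cc4n3)cc2)no1`, with chloro in place of hydrogen on an aromatic carbon, gives 5.91 nM, a step of a 1.9-fold higher number from compound 1 to compound 2 (0.28 log units; within the scatter). Compound 3 `CC(C)(C)c1cc(NC(=O)Nc2ccc(-c3cn4ccc(Br)cc4n3)cc2)no1` gives 9.59 nM, the highest of the three numbers; the step of a 3.1-fold higher number from compound 1 to compound 3 (0.49 log units; beyond the scatter) is beyond the scatter, while a 1.6-fold higher number from compound 2 to compound 3 (0.21 log units; within the scatter) is within it.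

Compound 4 `Cc1ccn2cc(-c3ccc(NC(=O)Nc4cc(C(C)(C)C)on4)cc3)nc2c1` differs from compound 3 by methyl in place of bromo on an aromatic carbon. Within the data shown here, no measured step exchanges bromo for methyl at that aromatic carbon. Among the measured compounds shown here, the steps that bear on it are a 3.1-fold higher number from compound 1 to compound 3 (0.49 log units; beyond the scatter) and a 1.6-fold higher number from compound 2 to compound 3 (0.21 log units; within the scatter), which show the bromo analogue at the upper end of the series and the unsubstituted compound 1 at the lower end; compound 2 sits between them within the scatter of both. Methyl is taken as a substituent of similar size to chloro, so compound 4 is expected to return a number near compound 2, with a step of a 1.7-fold lower number from compound 3 to compound 4 (0.24 log units; within the scatter) within the scatter. The estimate for compound 4 in this assay is 5.5 nM, in the range 2.5 nM to 12 nM.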

Compound 4, half-maximal inhibitory concentration: 0.79 nM
Compound 4: middle estimate off by 7.0-fold (0.84 log units), on the high side; measured number below the stated range.
By their numbers in this assay, from the lowest: compound 4; then compounds 1, 2 and 3 (each within the scatter of the next, the first and the last beyond it).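

At the ring carbon opposite the ring nitrogen, methyl parts sharply from both halogens in this assay, with a 12-fold lower number from compound 3 to compound 4 (1.08 log units; beyond the scatter) and a 7.5-fold lower number from compound 2 to compound 4 (0.87 log units; beyond the scatter), even though bromo and methyl each count one heavy atom, so that count does not order these compounds. Methyl also improves on hydrogen, with a 3.9-fold lower number from compound 1 to compound 4 (0.59 log units; beyond the scatter), which makes compound 4 the strongest of the four and shows that this position can gain from substitution, whereas a 3.1-fold higher number from compound 1 to compound 3 (0.49 log units; beyond the scatter) runs the other way for bromo. Nothing on hand explains why methyl and the halogens part here.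

The compounds shown leave open whether the gain extends to an ethyl, a methoxy or an amine at this carbon. They also leave open whether methyl would give a similar step at other carbons of that ring.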